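Series notes: removing the benzyl phenyl from compound 2

The compounds below may be only part of what the source reports. "The series", "measured", "known", "first", "only" and "open" are said of these compounds alone.

Measured in an assay for inhibition of MAP kinase-interacting serine/threonine-protein kinase 1 (Homo sapiens), read by luminescence and ADP-Glo, with a stated time of 2 h; on this read-out higher numbers stand for weaker inhibition and lower numbers for stronger inhibition:
compound 1 `O=c1ccc(-c2ccc3cn[nH]c3c2)cn1Cc1ccccc1C(F)(F)F` — 133 nM
compound 2 `O=c1ccc(-c2ccc3cn[nH]c3c2)cn1Cc1ccccc1` — 315 nM
compound 3 `CC(=O)Nc1cccc(Cn2cc(-c3ccc4cn[nH]c4c3)ccc2=O)c1` — 163 nM

Compound 2 carries the highest of the three numbers. Its separation from compound 1 is a 2.4-fold higher number from compound 1 to compound 2 (0.37 log units; beyond the scatter), beyond the scatter, whereas a 1.9-fold lower number from compound 2 to compound 3 (0.29 log units; within the scatter) stays within it.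

Compound 4 `Cn1cc(-c2ccc3cn[nH]c3c2)ccc1=O` differs from compound 2 by hydrogen in place of phenyl on a saturated chain carbon bound to an aromatic nitrogen. Both measured steps only alter a substituent on the phenyl that here leaves; neither removes the ring, so they bear on this change only loosely. Since a trifluoromethyl on that ring shifts the number by a 2.4-fold higher number from compound 1 to compound 2 (0.37 log units; beyond the scatter), the ring itself appears to contribute, and its loss is expected to weaken inhibition by more than that. The expected step is a 3.8-fold higher number from compound 2 to compound 4 (0.58 log units; beyond the scatter). Compound 4 is estimated at 1200 nM, within 350 nM to 5000 nM.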

Compound 4, half-maximal inhibitory concentration: > 2000 nM
Compound 4 was reported as a limit; the forecaster's own chance of this, stated with the estimate: 10%; middle value at least 1.6-fold (0.22 log units) away from the limit.
By their numbers in this assay, from the lowest: compounds 1, 3 and 2 (each within the scatter of the next, the first and the last beyond it). At a limit, above all of these: compound 4.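

Cutting benzyl back to methyl gives an at least 6.3-fold higher number from compound 2 to compound 4 (0.80 log units; beyond the scatter) as the first change in the series that removes the phenyl ring itself, not just a substituent on it. On these data alone, compound 4 gives > 2000 nM in this assay and this is a limit, so the full size of the step remains unknown. Compounds 1, 2 and 3 all keep the ring, and all three give lower numbers than the limit of compound 4.

The compounds shown leave open whether the ring must be aromatic. A cyclohexyl in place of phenyl, or a longer chain such as propyl in place of methyl, would address this.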